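Carbamate aryl variation on a PANC-1 inhibition read-out

The source may report more compounds than this note shows. Statements on the series, on what has been measured and on what is new or still open speak of the compounds shown alone.

Compound 1: `COc1cccc(NC(=O)Oc2cc(=O)n(CCCO)c3c2CC(CC=C(C)C)C(C)(C)C3)c1` — 16.2%
Compound 2: `CC(C)=CCC1Cc2c(OC(=O)Nc3cccc(F)c3)cc(=O)n(CCCO)c2CC1(C)C` — 66.1%

Two compounds share one core and differ only in the aryl group on the carbamate nitrogen. In a functional assay on PANC-1 cells (Homo sapiens) for inhibition, read by MTT assay, with a stated time of 24 h, tested at 10 uM (on this read-out higher numbers stand for more inhibition at the one concentration tested (going by the name of the read-out) and lower numbers for less inhibition), compound 1 gives 16.2%, while compound 2 gives 66.1%. Among the measured compounds shown here, the single measured step, a number 49.9 percentage points higher from compound 1 to compound 2 (beyond the scatter), comes from fluoro in place of methoxy on an aromatic carbon. On the numbers shown, compound 2 stands highest of the two, with compound 1 as its only neighbour, well beyond the scatter.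

Compound 3, `CC(C)=CCC1Cc2c(OC(=O)Nc3ccc(F)cc3F)cc(=O)n(CCCO)c2CC1(C)C`, is not yet measured in this assay. It differs from compound 2 by 2,4-difluorophenyl in place of 3-fluorophenyl on an amide-type nitrogen. For the measured compounds named here, no measured step shows a change from 3-fluorophenyl to 2,4-difluorophenyl, so the one step available bears on it only indirectly: it shows that the aryl group on the carbamate nitrogen can move the read-out strongly, but it says nothing about this particular exchange. On that basis compound 3 is expected to stay near compound 2, with the step of a number 11.1 percentage points lower from compound 2 to compound 3 (beyond the scatter) expected to lie within the scatter or a little below it. The estimate for compound 3 is 55%, within 30% to 80%.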

Compound 3, a percentage reported as inhibition, at one concentration (the size of the read-out at that concentration, not a potency): 69.7%
The estimate for compound 3 lay 14.7 percentage points below the measured number; low and high end bracket the measured number.
By their numbers in this assay, from the lowest: compound 1; then compounds 2 and 3 (each within the scatter of the next).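

In this assay the exchange of 3-fluorophenyl for 2,4-difluorophenyl on the amide-type nitrogen gives a number 3.6 percentage points higher from compound 2 to compound 3 (within the scatter) and so leaves compound 2 and compound 3 indistinguishable, which the earlier pair could not show: this position accepts a second fluorine without a measurable change in the read-out. The other new comparison, a number 53.5 percentage points higher from compound 1 to compound 3 (beyond the scatter) and thus a large one, shows that the gap first seen with the 3-methoxyphenyl group is not tied to 3-fluorophenyl alone but recurs with a second fluorinated aryl group. Among these three compounds, the two fluorinated aryl groups sit together and compound 1, with its 3-methoxyphenyl group, stands apart from both.

The compounds shown leave open whether an unsubstituted phenyl, a 3-chlorophenyl or a saturated cyclohexyl group on this nitrogen would sit with compound 2 and compound 3 or with compound 1. They also leave open how an amine or a carboxylic acid on the aryl ring would fare, and whether compound 2 and compound 3 would still match at other concentrations. No measurement at hand explains why the methoxy compound differs from the fluorinated ones.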